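Cytotoxicity on the shared core: pyridinylmethyl amine variant

This account rests on a few compounds, and the source may have more. Where it says the series, first, only, none or still open, it means among the compounds named here.

Compound 1 `CCCCOc1ccc(-c2nc3ncccn3c2NC(C)C)cc1` and compound 2 `CCCCOc1ccc(-c2nc3ncccn3c2Nc2ccc(F)cc2)cc1` share one core. In a toxicity assay on A549 cells (Homo sapiens) for cytotoxicity, read by luminescence and CellTiter-Glo, with a stated time of 48 h (a lower number here means that less compound is tolerated, a higher number that more compound is tolerated), compound 1 gives 68000 nM. In this assay compound 2 reports only a limit, > 100000 nM, marked by the limit of > 100000 nM in this assay, at which 1 of the 2 values shown sits. The step of an at least 1.4-fold higher number from compound 1 to compound 2 (0.16 log units; that floor lies within the scatter) is the only measured one here. Compound 3 `CCCCOc1ccc(-c2nc3ncccn3c2NCc2ccccn2)cc1` differs from compound 2 by (pyridin-2-yl)methyl in place of 4-fluorophenyl on a nitrogen on an aromatic ring. Among the measured compounds shown here, no measured step covers this change, so no shift beyond the scatter is expected in this assay. For compound 3 the expected value is 90000 nM (range 40000 nM to 200000 nM). The step of an at least 1.1-fold lower number from compound 2 to compound 3 (0.04 log units; that floor lies within the scatter) is expected to be flat.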

Compound 3, half-maximal cytotoxic concentration: > 100000 nM
Compound 3: no number, only a limit (the forecaster's own chance of this, stated with the estimate: 55%); middle value at least 1.1-fold (0.04 log units) from the limit.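

In this assay compound 3 reports only a limit, > 100000 nM, so (pyridin-2-yl)methyl on this nitrogen reaches the same limit as the 4-fluorophenyl of compound 2. Against the isopropyl of compound 1, the change reads as an at least 1.4-fold higher number from compound 1 to compound 3 (0.16 log units; that floor lies within the scatter). The step between compound 2 and compound 3 cannot be read because both values are limits: the limit of > 100000 nM in this assay, at which 2 of the 3 values shown sit.

As far as these compounds go, whether the pyridine nitrogen matters here stays open, since neither compound gives a number. The shared core also leaves open what a longer alkyl chain or a morpholine-bearing chain on this nitrogen would give.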